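The source may report more compounds than this note shows. Statements on the series, on what has been measured and on what is new or still open speak of the compounds shown alone.

Compound 1 `CCn1c(-c2ccccc2)nc2c(NC3CCC3)ncnc21`: 6 nM
Compound 2 `CCCn1c(-c2ccccc2)nc2c(NC3CCC3)ncnc21`: 15 nM
Compound 3 `Cn1c(-c2ccccc2)nc2c(NC3CCC3)ncnc21`: 3.2 nM

These three compounds share one core and were measured in an assay on CHO cells for displacement of a labelled ligand from adenosine receptor A1 (Homo sapiens), read by scintillation counting, with a stated time of 3 h; a lower number here means a stronger inhibitor, a higher number a weaker inhibitor. Compound 2 has the highest number of the three: the step of a 2.5-fold higher number from compound 1 to compound 2 (0.40 log units; beyond the scatter) and the step of a 4.7-fold lower number from compound 2 to compound 3 (0.67 log units; beyond the scatter) both lie beyond the scatter, whereas the step of a 1.9-fold lower number from compound 1 to compound 3 (0.27 log units; within the scatter) stays within it.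

Compound 4 `CCCn1c(-c2ccccc2)nc2c(N)ncnc21` has not yet been measured. It differs from compound 2 in one place: hydrogen in place of cyclobutyl on a nitrogen on an aromatic ring. Every measured step concerns only the saturated chain on the other aromatic nitrogen, where a longer chain went with a higher number; none of them touches the cyclobutylamino group, so the measured steps give no direct guide to the direction or size of this change. The change itself is larger than any measured one, as a whole ring leaves rather than a methyl or an ethyl, so a step beyond the scatter is more likely than not. Compound 4 is expected to move by a step of a 20-fold higher number from compound 2 to compound 4 (1.30 log units; beyond the scatter) in this assay, with wide uncertainty. The estimate for compound 4 in this assay is 300 nM, expected to lie between 40 nM and 3000 nM.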

Compound 4, inhibition constant: 101 nM
Beside the measured number, compound 4's estimate is 3.0-fold (0.47 log units) above it, within the range that was stated.
By their numbers in this assay, from the lowest: compounds 3 and 1 (each within the scatter of the next); then compound 2; then compound 4.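

Within the data shown here, replacing cyclobutylamino with amino on the shared core gives, in this assay, a 6.7-fold higher number from compound 2 to compound 4 (0.83 log units; beyond the scatter), so this is the first look at the nitrogen on an aromatic ring rather than at the saturated chain on the other aromatic nitrogen. The step lies beyond the scatter, which shows that the number responds to what sits on this nitrogen as well as to the chain, and that the compound carrying cyclobutyl has the lower number, meaning it is the stronger inhibitor of this pair. Compound 4 still gives a finite reading with only hydrogen on this nitrogen, but nothing available accounts for the size or direction of this step.

A single pair cannot show whether the ring size matters, so a cyclopentyl or cyclohexyl ring, or an open chain such as isopropyl, on this nitrogen remains an open question. The amino group also appears only with the propyl chain of compound 2, so whether the same change would give a similar step with the methyl chain of compound 3 or the ethyl chain of compound 1 is open too.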